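Three inactive aminopyrazoles and an untested acetyl analogue

The source may hold more compounds than are shown below. What is called first, only, known or untested is meant among the compounds shown, and "the series" means these compounds.

Compound 1, `Cc1[nH]nc(N)c1-c1ccc(Cl)c(Cl)c1`. In an assay on Sf9 cells for inhibition of inhibitor of nuclear factor kappa-B kinase subunit epsilon (Homo sapiens), read by ADP-Glo, with a stated time of 60 min (a lower number here means a stronger inhibitor, a higher number a weaker inhibitor), compound 1 gives > 100000 nM, which is a limit of the assay and not a number.
Compound 2, `Cc1n[nH]c(N)c1-c1ccc(Cl)cc1`. In this assay compound 2 gives > 100000 nM, again a limit of the assay.
Compound 3, `CC(=O)n1nc(C)c(-c2ccc(Cl)cc2)c1N`. In this assay compound 3 gives > 100000 nM, once more a limit of the assay.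

Compound 4, `CC(=O)n1nc(N)c(-c2ccc(Cl)c(Cl)c2)c1C`, has not yet been measured in this assay. It arises from compound 1 by the change (acetyl in place of hydrogen on an aromatic nitrogen). The same kind of change has already been made once among the measured compounds, from compound 2 to compound 3: acetyl in place of hydrogen on an aromatic nitrogen. Among the measured compounds shown here, the two places are not the same word for word: in the change from compound 2 to compound 3 the aromatic nitrogen is next to the ring atom that bears an amino group and two ring bonds from the ring atom that bears a methyl group and from the one bearing a group of 7 heavy atoms, whereas in the change from compound 1 to compound 4 it is next to the ring atom that bears a methyl group and two ring bonds from the ring atom that bears an amino group and from the one bearing a group of 8 heavy atoms. The difference between the two cores of compound 1 and compound 2 is not broken down here.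

The measured step is a step that the two limits leave unreadable from compound 2 to compound 3. This rests on (the limit of > 100000 nM in this assay, at which 3 of the 3 values shown sit).

With both values at the limit, the step from compound 1 to compound 4 is expected to be a number no higher from compound 1 to compound 4 (the limit leaves the size open). Compound 4 is therefore estimated at 100000 nM, most likely reported again as a limit, within a range expected between 30000 nM and 300000 nM.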

Compound 4, half-maximal inhibitory concentration: > 100000 nM
Compound 4: only a limit was reported; the forecaster's own chance of this, stated with the estimate: 85%; the middle value lies on the limit itself.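

In this assay compound 4 gives > 100000 nM, which is a limit of the assay and not a number. Compound 1 and compound 4 both sit at a limit, so no step can be read between them: the limit of > 100000 nM in this assay, at which 4 of the 4 values shown sit. The compounds shown leave open what acetyl in place of hydrogen on an aromatic nitrogen does to a compound with a measurable value in this assay.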